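The source may report more compounds than this note shows. Statements on the series, on what has been measured and on what is new or still open speak of the compounds shown alone.

Working notes on the series. In an assay on isolated protein for inhibition of glutathione S-transferase Mu 2 (Homo sapiens), with a stated time of 10 min (on this read-out lower numbers stand for stronger inhibition and higher numbers for weaker inhibition), compound 1 `O=C(CCC(=O)OCCCCCCSc1ccc([N+](=O)[O-])c2nonc12)Nc1ccccc1F` gives 350 nM. Compound 2 `Cc1ccc(NC(=O)CCC(=O)OCCCCCCSc2ccc([N+](=O)[O-])c3nonc23)cc1` gives 390 nM in this assay. Compound 3 `COc1ccc(NC(=O)CCC(=O)OCCCCCCSc2ccc([N+](=O)[O-])c3nonc23)cc1` gives 130 nM, the lowest of the three numbers, with both neighbours beyond the scatter. The move a 2.7-fold lower number from compound 1 to compound 3 (0.43 log units; beyond the scatter) and the move a 3.0-fold lower number from compound 2 to compound 3 (0.48 log units; beyond the scatter) both altered the aryl group on the amide nitrogen, whereas a 1.1-fold higher number from compound 1 to compound 2 (0.05 log units; within the scatter). Compound 4 `O=C(CCC(=O)OCCCCCCSc1ccc([N+](=O)[O-])c2nonc12)Nc1ccc(F)c(Cl)c1` carries the change (3-chloro-4-fluorophenyl in place of 4-methoxyphenyl on an amide-type nitrogen). The two informative steps, a 2.7-fold lower number from compound 1 to compound 3 (0.43 log units; beyond the scatter) and a 3.0-fold lower number from compound 2 to compound 3 (0.48 log units; beyond the scatter), suggest the methoxy-bearing ring is what set compound 3 apart, so giving it up for a halogenated ring is expected to push the number back up by a modest step in this assay. Compound 4 is therefore estimated at 350 nM, range 150 nM to 800 nM, meaning a 2.7-fold higher number from compound 3 to compound 4 (0.43 log units; beyond the scatter).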

Compound 4, half-maximal inhibitory concentration: 470 nM
For compound 4 the middle estimate is 1.3-fold (0.13 log units) below the measured one; low and high end bracket the measured number.
By their numbers in this assay, from the lowest: compound 3; then compounds 1, 2 and 4 (each within the scatter of the next).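

In this assay the advantage of compound 3 does not survive replacing 4-methoxyphenyl with 3-chloro-4-fluorophenyl on the amide-type nitrogen (a 3.6-fold higher number from compound 3 to compound 4 (0.56 log units; beyond the scatter)), leaving compound 3 beyond the scatter from all three other compounds. The new ring is not separated from 4-methylphenyl (a 1.2-fold higher number from compound 2 to compound 4 (0.08 log units; within the scatter)) or 2-fluorophenyl (a 1.3-fold higher number from compound 1 to compound 4 (0.13 log units; within the scatter)). No evidence bears on the cause of these differences.

From the compounds shown here alone, only compound 3 carries a methoxy group, so it remains open whether a 4-ethoxyphenyl or 4-hydroxyphenyl ring would behave likewise. Going by these compounds, whether the ranking holds with a shorter linking chain also remains open.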